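Chain length and piperidine cap in a flavone series

A few compounds are considered here, and "the series" means these few. Any claim that something is new, unique, unknown or untested is made for them only; others in the source may bear on it.

In a functional assay for inhibition, read by fluorescence and spectrophotometry, with a stated time of 30 h (a lower number here means a stronger inhibitor, a higher number a weaker inhibitor), compound 1 `COc1ccc(-c2cc(=O)c3ccc(OCCCCCN4CCC(CCO)CC4)cc3o2)cc1` gives 49400 nM. Compound 2 `COc1ccc(-c2cc(=O)c3ccc(OCCCCCCN4CCC(C)CC4)cc3o2)cc1` gives 57200 nM in this assay, and compound 3 `COc1ccc(-c2cc(=O)c3ccc(OCCCCCCN4CCC(CCO)CC4)cc3o2)cc1` gives 50400 nM. The three numbers sit close together: a 1.2-fold higher number from compound 1 to compound 2 (0.06 log units; within the scatter), a 1.0-fold higher number from compound 1 to compound 3 (0.01 log units; within the scatter), and a 1.1-fold lower number from compound 2 to compound 3 (0.05 log units; within the scatter).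

The change from compound 1 to compound 2 is (4-methylpiperidin-1-yl)methyl in place of 4-(2-hydroxyethyl)piperidin-1-yl on a saturated chain carbon, five bonds along the chain from an oxygen on an aromatic ring. The same kind of change leads from compound 3 to compound 4 `COc1ccc(-c2cc(=O)c3ccc(OCCCCCCCN4CCC(C)CC4)cc3o2)cc1`, not yet measured in this assay: (4-methylpiperidin-1-yl)methyl in place of 4-(2-hydroxyethyl)piperidin-1-yl on a saturated chain carbon, six bonds along the chain from an oxygen on an aromatic ring. The two cores differ by (4-(2-hydroxyethyl)piperidin-1-yl)methyl in place of 4-(2-hydroxyethyl)piperidin-1-yl on a saturated chain carbon, five bonds along the chain from an oxygen on an aromatic ring. The place is not the same: in the first pair the change sits on a saturated chain carbon, five bonds along the chain from an oxygen on an aromatic ring, in the second pair six bonds along the chain from an oxygen on an aromatic ring.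

The expected step is a 1.2-fold higher number from compound 3 to compound 4 (0.06 log units; within the scatter), beside a 1.2-fold higher number from compound 1 to compound 2 (0.06 log units; within the scatter). This rests on compound 1 at 49400 nM and compound 2 at 57200 nM staying within scatter of each other. For compound 4 the expected value is 58000 nM, in a range from 35000 nM to 95000 nM.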

Compound 4, half-maximal inhibitory concentration: 61600 nM
Compound 4: the middle estimate sits 1.1-fold (0.03 log units) below what was measured; the measured number falls inside the stated range.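

In this assay the same change on the two cores gives steps that cannot be told apart: the same change on two cores in this assay, a 1.2-fold higher number (0.06 log units; within the scatter) from compound 1 to compound 2 and a 1.2-fold higher number (0.09 log units; within the scatter) from compound 3 to compound 4, 1.1-fold (0.02 log units) apart, within the scatter of two such steps

The new steps read a 1.2-fold higher number from compound 3 to compound 4 (0.09 log units; within the scatter) and a 1.1-fold higher number from compound 2 to compound 4 (0.03 log units; within the scatter) and also a 1.2-fold higher number from compound 1 to compound 4 (0.10 log units; within the scatter) and all three lie within the scatter, so these compounds cannot be put in order. The agreement therefore shows only that replacing the 4-(2-hydroxyethyl)piperidin-1-yl end with the 4-methylpiperidine end gives no readable step on either core; it does not show that a step of real size would carry from one core to another, since two steps within the scatter can agree without any effect behind them.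

Still open, going by these compounds, is whether a carboxylic acid or an amine in place of the hydroxyl of the 2-hydroxyethyl group would give a number beyond the scatter in this assay on these cores. Also open, on these data alone, is whether a longer chain or a much shorter one would do so.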